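Second methoxy on the amide aryl ring of compound 2

The source may report more compounds than this note shows. Statements on the series, on what has been measured and on what is new or still open speak of the compounds shown alone.

Measured so far:
compound 1 `COc1ccc(/C=N/N(C)C(=O)c2ccccc2OC)cc1OC` — 53%
compound 2 `COc1cccc(C(=O)N(C)/N=C/c2ccc(OC)c(OC)c2)c1` — 77%
compound 3 `COc1ccc(/C=N/N(C)c2ncnc3ccccc23)cc1OC` — 49%

In a functional assay on the whole organism (lung, strain A/J) for inhibition, with Mus musculus as the target, with stated times of 1 h and 18 h, at a dose of 100 umol/kg by the oral route (a higher number here means more inhibition at the dose given (going by the name of the read-out), a lower number less inhibition), compound 2 stands highest of the three numbers; compound 1 is nearest, and compound 3 is furthest. Both gaps to compound 2 are beyond the scatter, so compound 2 gives the highest number of the measured set on this read-out.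

Compound 4 `COc1ccc(/C=N/N(C)C(=O)c2ccc(OC)c(OC)c2)cc1OC` is not yet measured. It differs from compound 2 in one place: methoxy in place of hydrogen on an aromatic carbon, the new group sitting ortho to a methoxy group and para to a large group.

Within the data shown here, the only measured step at this assay that touches the amide aryl ring is a number 24 percentage points higher from compound 1 to compound 2 (beyond the scatter), which moves a methoxy rather than adding one. Among the measured compounds shown here, no measured pair adds a second methoxy to a ring that already carries one, so no step bears directly on the change to compound 4. Compound 3 carries a different core and gives no guidance on this ring.

With one step of modest size as the only reference and none for the change itself, the expectation for compound 4 is a number near that of compound 2, with the step of a number 7 percentage points lower from compound 2 to compound 4 (within the scatter) expected to lie within the scatter. The estimate for compound 4 in this assay is 70%, within 50% to 88%.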

Compound 4, a percentage reported as inhibition, in the whole organism at one dose (the size of the read-out at that dose, not a potency): 50%
For compound 4 the middle estimate is 20 percentage points above the measured one; low and high end bracket the measured number.
By their numbers in this assay, from the lowest: compounds 3, 4 and 1 (each within the scatter of the next); then compound 2.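

In this assay the step is a number 27 percentage points lower from compound 2 to compound 4 (beyond the scatter) and lies beyond the scatter, so methoxy in place of hydrogen at this place, ortho to a methoxy group and para to a large group, is not a neutral change on the amide aryl ring of compound 2. The earlier step, a number 24 percentage points higher from compound 1 to compound 2 (beyond the scatter), involved only a shift of the single methoxy on that ring, whereas this new step shows that a second methoxy added to the ring of compound 2 gives less inhibition at the dose given. No measurement at hand offers a reason for this drop.

From the compounds shown here alone, it remains open whether the loss belongs to methoxy specifically or to any group at this place, and a fluorine atom, a hydroxyl group or an amine on the same aromatic carbon would separate those two readings. Going by these compounds, it also remains open whether the same addition gives a similar step on a ring whose first methoxy sits elsewhere, as it does in compound 1.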